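A few compounds are considered here, and "the series" means these few. Any claim that something is new, unique, unknown or untested is made for them only; others in the source may bear on it.

Values in a functional assay on MDA-MB-231 cells (Homo sapiens) for inhibition, read by MTT assay, with a stated time of 48 h; on this read-out lower numbers stand for stronger inhibition and higher numbers for weaker inhibition:
- compound 1 `O=C(CCCCCNC(=O)Cn1cnc2c(NCc3ccccc3)ncnc21)NO`: 34200 nM
- compound 2 `O=C(CCCCCNC(=O)Cn1cnc2c(Nc3ccccc3)ncnc21)NO`: 22300 nM
- compound 3 `O=C(CCCCNC(=O)Cn1cnc2c(Nc3ccccc3)nc(Nc3ccccc3)nc21)NO`: 11100 nM

Compound 3 lies within the scatter of compound 2, and its number is lower than that of compound 1 by more than the scatter. The next structure is compound 4 `O=C(CCCCCNC(=O)Cn1cnc2c(Nc3ccccc3)nc(Nc3ccccc3)nc21)NO`, which is still to be measured in this assay. The change is (hydroxycarbamoyl)methyl in place of hydroxycarbamoyl on a saturated chain carbon, four bonds along the chain from an amide-type nitrogen: the 3-(hydroxycarbamoyl)propyl chain becomes 4-(hydroxycarbamoyl)butyl, and the rest of the structure stays the same.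

Among the compounds with values here, the one measured step between single-place analogues, a 1.5-fold lower number from compound 1 to compound 2 (0.19 log units; within the scatter), is a change of phenyl in place of benzyl on a nitrogen on an aromatic ring. It lies within the scatter and sits elsewhere in the structure, so it bears only loosely on this change. Within the data shown here, no measured step covers the chain change itself. No shift beyond the scatter is therefore expected, and no direction can be favoured. The expected step is a 1.0-fold lower number from compound 3 to compound 4 (0.00 log units; within the scatter). For compound 4 the estimated value is 11000 nM, with an expected range of 5000 nM to 24000 nM.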

Compound 4, half-maximal inhibitory concentration: 1610 nM
Estimate against measurement, compound 4: 6.8-fold (0.83 log units) above; the whole stated range lies above it.
By their numbers in this assay, from the lowest: compound 4; then compounds 3, 2 and 1 (each within the scatter of the next, the first and the last beyond it).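

Within the data shown here, the chain position is sensitive in this assay: going from 3-(hydroxycarbamoyl)propyl to 4-(hydroxycarbamoyl)butyl gives a 6.9-fold lower number from compound 3 to compound 4 (0.84 log units; beyond the scatter), the first step between single-place analogues to lie beyond the scatter. With the 4-(hydroxycarbamoyl)butyl chain held constant, anilino in place of hydrogen on an aromatic carbon gives a 14-fold lower number from compound 2 to compound 4 (1.14 log units; beyond the scatter), an effect that could not be separated from chain length earlier, since compound 3 differs from compound 2 in two places. Nothing available explains either step.

Still open, from the compounds shown here alone, is whether a longer chain, such as 5-(hydroxycarbamoyl)pentyl, would extend or reverse the chain-length step. Also open, going by these compounds, is how a carboxylic acid in place of the hydroxycarbamoyl end group would read in this assay.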